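Carbonyl substituent variation on the shared core

The source may report more compounds than this note shows. Statements on the series, on what has been measured and on what is new or still open speak of the compounds shown alone.

Compound 3 `COC1CC(C(=O)N2CCc3nc(C#Cc4ccccc4)sc3C2)C1` gives the highest of the two numbers in an assay on HEK293 cells for positive allosteric modulation of metabotropic glutamate receptor 5 (Homo sapiens), read by FLIPR, with a stated time of 1 h (on this read-out lower numbers stand for an effect already at smaller amounts and higher numbers for an effect only at larger amounts of compound), at 640 nM. Compound 2 `O=C(C1CC12CCC2)N1CCc2nc(C#Cc3ccccc3)sc2C1` gives 3.9 nM; the step of a 160-fold higher number from compound 2 to compound 3 (2.22 log units; beyond the scatter). Compound 1 `O=C(C1CC1)N1CCc2nc(C#Cc3ccccc3)sc2C1` sits at a limit of the assay, > 10000 nM, as noted in the limit of > 10000 nM in this assay, at which 1 of the 3 values shown sits. Against that limit, the step of an at least 15-fold lower number from compound 1 to compound 3 (1.19 log units; beyond the scatter) and the step of an at least 2500-fold lower number from compound 1 to compound 2 (3.40 log units; beyond the scatter).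

Compound 4 `CC1CCC(C(=O)N2CCc3nc(C#Cc4ccccc4)sc3C2)CC1` carries 4-methylcyclohexyl in place of 3-methoxycyclobutyl on a carbonyl carbon. Every measured step in this series changes the group on the same carbonyl carbon, and every one is large: enlarging cyclopropyl gave lower numbers in both directions tried, and swapping the spiro group for 3-methoxycyclobutyl gave a higher one. A larger ring without the methoxy group points to a lower number than compound 3, though how far is not fixed by the measured steps. The expected step is a 6.4-fold lower number from compound 3 to compound 4 (0.81 log units; beyond the scatter). Compound 4 is therefore estimated at 100 nM in this assay, within 20 nM to 600 nM.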

Compound 4, half-maximal effective concentration: 190 nM
Estimate against measurement, compound 4: 1.9-fold (0.28 log units) below; measured number inside the range.
By their numbers in this assay, from the lowest: compound 2; then compound 4; then compound 3. At a limit, above all of these: compound 1.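

Going from 3-methoxycyclobutyl to 4-methylcyclohexyl on this carbonyl carbon, which removes the one hydrogen-bond acceptor of the group and adds a heavy atom, gives only a 3.4-fold lower number from compound 3 to compound 4 (0.53 log units; beyond the scatter) in this assay. Heavy-atom count alone therefore does not order these groups: 4-methylcyclohexyl carries more heavy atoms than the group of compound 2, yet the result is a 49-fold higher number from compound 2 to compound 4 (1.69 log units; beyond the scatter), while the change from cyclopropyl gives an at least 52-fold lower number from compound 1 to compound 4 (1.72 log units; beyond the scatter). Compound 1 stands at a limit, not a number: the limit of > 10000 nM in this assay, at which 1 of the 4 values shown sits.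

The change from compound 3 to compound 4 alters ring size and ring substituent at once, and the share of each cannot be read. As far as these compounds go, how an amine or a longer open chain on this carbonyl carbon would stand remains open.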